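The source may report more compounds than this note shows. Statements on the series, on what has been measured and on what is new or still open speak of the compounds shown alone.

Measured compounds: compound 1 `COc1ccc2nccc(CC[C@H]3OC[C@H](NCc4ccc5c(n4)NC(=O)CO5)CO3)c2c1`, 24000 nM; compound 2 `COc1ccc2nccc(CC[C@H]3CC[C@H](NCc4ccc(Cl)c(Cl)c4)CC3)c2c1`, "not determined" (no result reported).

In an ADME assay on K562 cells (Homo sapiens) for antiproliferative activity (on this read-out higher numbers stand for weaker inhibition and lower numbers for stronger inhibition), compound 1 gives 24000 nM. In this assay compound 2 gives "not determined" (no result reported), so it stands without a number there. Compound 3 `COc1ccc2nccc(CC[C@H]3CC[C@H](NCc4ccc5c(c4)OCCO5)CC3)c2c1` differs from compound 2 in one place: 2,3-dihydro-1,4-benzodioxin-6-yl in place of 3,4-dichlorophenyl on a saturated chain carbon bound to an amine nitrogen. Going by the values given here, no measured pair shows this change, so the size of the step from compound 2 to compound 3 in this assay cannot be read from the data; a step beyond the scatter in either direction remains possible. Compound 3 is estimated at 10000 nM, expected to fall between 2000 nM and 50000 nM.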

Compound 3, half-maximal inhibitory concentration: 4200 nM
The estimate for compound 3 lay 2.4-fold (0.38 log units) above the measured number; the range from low to high includes it.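

Going by these compounds alone, no step from compound 2 to compound 3 can be read from these results. Going by these compounds, what replacing 3,4-dichlorophenyl with 2,3-dihydro-1,4-benzodioxin-6-yl does to antiproliferative activity stays open. No evidence shown bears on the result.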